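Ethyl to cyclopropyl on the aromatic nitrogen

The source may report more compounds than this note shows. Statements on the series, on what has been measured and on what is new or still open speak of the compounds shown alone.

In a functional assay on A549 cells (Homo sapiens) for antiproliferative activity, read by MTT assay, with a stated time of 72 h (a higher number here means a weaker inhibitor, a lower number a stronger inhibitor), compound 1 (`Cc1ccc(S(=O)(=O)NC(=N)N2CCN(c3cc4c(cc3F)c(=O)c(C(=O)O)cn4C3CC3)CC2)cc1`) gives 71 nM and compound 2 (`CCn1cc(C(=O)O)c(=O)c2cc(F)c(N3CCN(C(=N)NS(=O)(=O)c4ccccc4Cl)CC3)cc21`) gives 71 nM at the same level. Compound 3 (`N=C(NS(=O)(=O)c1ccccc1Cl)N1CCN(c2cc3c(cc2F)c(=O)c(C(=O)O)cn3C2CC2)CC1`) carries cyclopropyl in place of ethyl on an aromatic nitrogen of compound 2 (cyclopropyl in place of ethyl on an aromatic nitrogen). Going by the values given here, no measured pair isolates this change. Compound 3 differs elsewhere from compound 1, which also bears cyclopropyl, and in this assay compound 1 gives 71 nM without departing from compound 2. The expected step of a 1.2-fold lower number from compound 2 to compound 3 (0.07 log units; within the scatter) stays within the scatter. Compound 3 is estimated at 60 nM with a range from 25 nM to 150 nM in this series.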

Compound 3, half-maximal inhibitory concentration: 71 nM
Beside the measured number, compound 3's estimate is 1.2-fold (0.07 log units) below it; low and high end bracket the measured number.
By their numbers in this assay, from the lowest: compounds 1, 2 and 3 (each within the scatter of the next).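

The pair isolates the nitrogen substituent: cyclopropyl in place of ethyl gives no change at the digits printed from compound 2 to compound 3 (within the scatter) in this assay and so leaves the antiproliferative read-out at this position unmoved. The second pair isolates the sulfonyl aryl group: 2-chlorophenyl in place of 4-methylphenyl gives no change at the digits printed from compound 1 to compound 3 (within the scatter) on the same cyclopropyl background. No data at hand offer an explanation for either result. Still open, as far as these compounds go, is how a longer chain such as n-butyl would read on the aromatic nitrogen. Also open, from the compounds shown here alone, is how a simple methyl would read on the sulfonyl sulfur.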